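A few compounds are considered here, and "the series" means these few. Any claim that something is new, unique, unknown or untested is made for them only; others in the source may bear on it.

Working notes on the series. Among the compounds with values here, compound 2 `Cc1ccc(OCC(=O)N(Cc2cccs2)c2ccn[nH]2)cc1` carries a 1H-pyrazol-5-yl group on the amide-type nitrogen; in an assay on HEK293 cells for agonist activity at transient receptor potential cation channel subfamily M member 8 (Homo sapiens), read by fluorescence and calcium flux, with a stated time of 15 min (a lower number here means that less compound is needed, a higher number that more compound is needed for the effect), compound 2 gives 0.2 nM, the lowest of the two numbers measured so far. Its nearest measured neighbour is compound 1 `Cc1ccc(OCC(=O)N(Cc2cccs2)C2CCCCC2)cc1`, which carries cyclohexyl at the same nitrogen and in this assay gives 40000 nM. Within the data shown here, the single step between them is a 200000-fold lower number from compound 1 to compound 2 (5.30 log units; beyond the scatter), a very large shift attached entirely to what sits on that nitrogen.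

Compound 3 `Cc1ccc(OCC(=O)N(CCCO)Cc2cccs2)cc1` has not yet been measured. It differs from compound 2 by 3-hydroxypropyl in place of 1H-pyrazol-5-yl on an amide-type nitrogen. Among the measured compounds shown here, the only measured step bearing on this position is the one from compound 1 to compound 2, and it shows that the nitrogen substituent can move the number across an enormous span; compound 1 demonstrates that a substituent other than 1H-pyrazol-5-yl can land far up the scale. For the measured compounds named here, with no second example at this position, the expectation for compound 3 is wide.

Compound 3 is expected to give about 10000 nM in this assay, within roughly 300 nM to 100000 nM. The step from compound 2 to compound 3 is accordingly expected to be a 50000-fold higher number from compound 2 to compound 3 (4.70 log units; beyond the scatter), a marked rise in the number.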

Compound 3, half-maximal effective concentration: 3000 nM
Compound 3: the middle estimate sits 3.3-fold (0.52 log units) above what was measured, within the range that was stated.
By their numbers in this assay, from the lowest: compound 2; then compound 3; then compound 1.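

In this assay the move from the 1H-pyrazol-5-yl group to the open 3-hydroxypropyl chain on the amide-type nitrogen costs almost the whole span seen so far (see a 15000-fold higher number from compound 2 to compound 3 (4.18 log units; beyond the scatter)), even though the two groups have the same hydrogen-bond donor and acceptor counts, so those counts alone do not hold the number down. The nitrogen substituent also matters among the groups other than 1H-pyrazol-5-yl, since replacing cyclohexyl with 3-hydroxypropyl still gives a change beyond the scatter (see a 13-fold lower number from compound 1 to compound 3 (1.12 log units; beyond the scatter)), and compound 1 is no longer the only high point at this position. No measurement bearing on the cause of either step is available.

As far as these compounds go, whether the low number of compound 2 belongs to the 1H-pyrazol-5-yl group itself or would also come with another aromatic ring, such as phenyl or imidazolyl, remains open. Also open, from the compounds shown here alone, is whether a 3-aminopropyl chain, a carboxylic acid on a chain, or a longer hydroxyalkyl chain would move the number away from that of compound 3.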